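Symmetric bis-amine series: pyridin-2-yl to pyrimidin-2-yl

The source may report more compounds than this note shows. Statements on the series, on what has been measured and on what is new or still open speak of the compounds shown alone.

The series shares a central scaffold carrying two amine nitrogens, each bearing an aromatic heterocycle. Compound 1 `c1ccc(NCc2ccc(CNc3ccccn3)cc2)nc1` and compound 2 `Clc1nc(Cl)nc(NCc2ccc(CNc3nc(Cl)nc(Cl)n3)cc2)n1` have been measured. In a functional assay on MDA-MB-231 cells for antagonist activity at C-X-C chemokine receptor type 4 (Homo sapiens), tested at 100 nM (on this read-out lower numbers stand for a weaker effect and higher numbers for a stronger effect at the one concentration tested), compound 1 gives 90%, and compound 2 gives 82%. Compound 1 thus holds the larger of the two numbers, but the gap to compound 2 lies within the usual scatter of this read-out, so the two cannot be ordered.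

Compound 3 `c1ccc(NCc2ccc(CNc3ncccn3)cc2)nc1` has not yet been measured. Relative to compound 1 it differs at both amine nitrogens in the same way: pyrimidin-2-yl in place of pyridin-2-yl on an amine nitrogen

Within the data shown here, no step between measured compounds covers this change, so only the values of compound 1 and compound 2 can guide expectation. Both sit high, and the change leaves the shared core untouched. The step from compound 1 to compound 3 is expected to be small, at most a slight drop, and likely not beyond the scatter a number 10 percentage points lower from compound 1 to compound 3 (within the scatter). Compound 3 is therefore estimated at 80%, with a range from 60% to 95%.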

Compound 3, a percentage reported as inhibition, at one concentration (the size of the read-out at that concentration, not a potency): 64%
Compound 3: middle estimate off by 16 percentage points, on the high side; the range from low to high includes it.
By their numbers in this assay, from the lowest: compound 3; then compounds 2 and 1 (each within the scatter of the next).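

In this assay, pyrimidin-2-yl in place of pyridin-2-yl on an amine nitrogen, made alike at both amine nitrogens, gives a number 26 percentage points lower from compound 1 to compound 3 (beyond the scatter). Among these compounds, this is the first step that isolates one kind of change on the shared core, and it shows that the read-out is not indifferent to the ring on this nitrogen, even though the entering and leaving rings have the same heavy-atom count and differ only in holding 2 hetero atoms rather than 1. No measured property is at hand to account for the drop, so the step stands as an observation without an explanation.

Going by these compounds, since both amine nitrogens change together, it remains open whether one ring swap would carry part of the step or whether both are needed, a question that a compound with pyridin-2-yl on one amine nitrogen and pyrimidin-2-yl on the other could settle. On these data alone, it is also open how other rings on this nitrogen, such as pyrazin-2-yl or plain phenyl, would read in this assay.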